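A few compounds are considered here, and "the series" means these few. Any claim that something is new, unique, unknown or untested is made for them only; others in the source may bear on it.

Measured compounds and their values:

- Compound 1, `CC1=CC[C@H](C(C)C)c2cc(C)c(OC(=O)c3ccc([N+](=O)[O-])cc3)cc21`: 72.9%
- Compound 2, `CC1=CC[C@H](C(C)C)c2cc(C)c(OC(=O)c3cccc(Cl)c3)cc21`: 40.4%
- Compound 3, `CC1=CC[C@H](C(C)C)c2cc(C)c(OC(=O)c3cccc(C(F)(F)F)c3)cc21`: 86%

All three share one core and differ only in the group attached to the carbonyl carbon of the ester. In a functional assay on MCF7 cells (Homo sapiens) for antiproliferative activity, read by sulforhodamine B assay, with a stated time of 48 h, tested at 50 uM (a lower number here means less inhibition, a higher number more inhibition at the concentration tested (going by the name of the read-out)), compound 3 gives 86%, the highest of the three numbers, and both of its gaps to the others are beyond the scatter. The two measured steps are large: a number 32.5 percentage points lower from compound 1 to compound 2 (beyond the scatter), and then a number 45.6 percentage points higher from compound 2 to compound 3 (beyond the scatter).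

Compound 4, `CC1=CC[C@H](C(C)C)c2cc(C)c(OC(=O)c3cccc(C)c3)cc21`, has not yet been measured. It differs from compound 3 in one place: methyl in place of trifluoromethyl on an aromatic carbon. For the measured compounds named here, no measured pair shows a trifluoromethyl exchanged for a methyl, so the only guide is the step from compound 2 to compound 3, where a different group at that same place changed the number by a large amount. That step says the group at this position matters, but not in which direction a methyl will move the number. A step downward from the highest value seems more likely than a further rise, and the expectation for compound 4 is therefore a number 28 percentage points lower from compound 3 to compound 4 (beyond the scatter), with wide uncertainty. The estimated value for compound 4 is 58%, expected to lie between 30% and 82%.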

Compound 4, a percentage reported as inhibition, at one concentration (the size of the read-out at that concentration, not a potency): 54.9%
The estimate for compound 4 lay 3.1 percentage points above the measured number; low and high end bracket the measured number.
By their numbers in this assay, from the lowest: compound 2; then compound 4; then compound 1; then compound 3.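

In this assay this spot on the ring has now carried three different groups, and exchanging trifluoromethyl for methyl costs a large part of the inhibition (a number 31.1 percentage points lower from compound 3 to compound 4 (beyond the scatter)). Methyl does not simply behave like chloro at this spot, since it still gives a modest gain over that group (a number 14.5 percentage points higher from compound 2 to compound 4 (beyond the scatter)), so the three groups give three separate levels, with methyl in the middle and trifluoromethyl on top. The 3-methylphenyl ester also stays modestly short of the 4-nitrophenyl ester (a number 18 percentage points lower from compound 1 to compound 4 (beyond the scatter)), which means that compound 3 is the only one of the four to rise above compound 1.

Nothing measured alongside these numbers bears on why the groups fall in this order. The compounds shown leave open where a methoxy group, an amine or a carboxylic acid at the same spot would fall among these three levels, and whether the order would hold in a full potency measurement rather than a reading at a single concentration.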